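The source may hold more compounds than are shown below. What is called first, only, known or untested is meant among the compounds shown, and "the series" means these compounds.

Working notes on the dithiocarbamate series.

Three compounds have numbers in a functional assay on LM7 cells (Homo sapiens) for antiproliferative activity, read by MTT assay, with a stated time of 72 h; on this read-out higher numbers stand for weaker inhibition and lower numbers for stronger inhibition. Compound 2 `O=c1c(CSC(=S)N2CCCCC2)coc2cc(Cl)ccc12` gives 850 nM, the lowest of the three. Compound 1 `COc1ccc2occ(CSC(=S)N(C(C)C)C(C)C)c(=O)c2c1` gives 4700 nM, and compound 3 `COc1ccc2occ(CSC(=S)N3CCCC3)c(=O)c2c1` gives 6000 nM; compound 1 and compound 3 share the core of compound 1 and differ only at the amine on the thiocarbonyl carbon, and that step, pyrrolidin-1-yl in place of diisopropylamino, came out as a 1.3-fold higher number from compound 1 to compound 3 (0.11 log units; within the scatter). Compound 2 differs from both in two places at once, so its gap to them cannot be assigned to either place on its own.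

Compound 4 `CC(C)N(C(=S)SCc1coc2cc(Cl)ccc2c1=O)C(C)C` is not yet measured. It keeps the core of compound 2 and changes only the amine: diisopropylamino in place of piperidin-1-yl on a thiocarbonyl carbon. Within the data shown here, the one measured step that bears on this position, from compound 1 to compound 3, stayed within the scatter, so no step beyond the scatter is expected here either; the expected step is a 1.1-fold higher number from compound 2 to compound 4 (0.02 log units; within the scatter). Compound 4 is therefore estimated at 900 nM in this assay, with a range from 400 nM to 2000 nM.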

Compound 4, half-maximal inhibitory concentration: > 25000 nM
Compound 4 was reported as a limit (the forecaster's own chance of this, stated with the estimate: 0%); middle value at least 27-fold (1.44 log units) from the limit.
By their numbers in this assay, from the lowest: compound 2; then compounds 1 and 3 (each within the scatter of the next). At a limit, above all of these: compound 4.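

On the core of compound 2, the amine on the thiocarbonyl carbon proves to be a position that matters in this assay: diisopropylamino in place of piperidin-1-yl gives an at least 29-fold higher number from compound 2 to compound 4 (1.46 log units; beyond the scatter). Compound 4 has a limit here and not a number: the limit of > 25000 nM in this assay, at which 1 of the 4 values shown sits. The earlier amine change on the core of compound 1, a 1.3-fold higher number from compound 1 to compound 3 (0.11 log units; within the scatter), stayed within the scatter, so that flat result does not carry over to the core of compound 2.

Still open, as far as these compounds go, is whether any amine without a ring loses activity on the core of compound 2, or only diisopropylamino does. A dimethylamino group or a morpholin-4-yl ring on that core would separate these readings, and pyrrolidin-1-yl there would link the two cores directly.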